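The source may hold more compounds than are shown below. What is called first, only, known or untested is meant among the compounds shown, and "the series" means these compounds.

Working notes on the series. Compound 3 `Cc1c(OCCCCOc2ccc(C(=O)O)c(Cl)c2)ccc(C(=O)CC2CCCC2)c1O` gives 510 nM in an assay on HEK293 cells for positive allosteric modulation of metabotropic glutamate receptor 2 (Rattus norvegicus), read by thallium flux, with a stated time of 2.5 min (on this read-out higher numbers stand for an effect only at larger amounts of compound and lower numbers for an effect already at smaller amounts), the highest of the three numbers recorded; compound 1 `Cc1cc(C(=O)O)ccc1OCCCCOc1ccc(C(=O)CC(C)C)c(O)c1C` gives 192 nM and compound 2 `Cc1c(OCCCCOc2ccc(C(=O)O)cc2Cl)ccc(C(=O)CC(C)C)c1O` gives 96 nM in this assay, both beyond the scatter below compound 3. Within the data shown here, the one measured step, a 2.0-fold lower number from compound 1 to compound 2 (0.30 log units; within the scatter), changes an aromatic substituent only and leaves the ketone side chain untouched.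

Compound 4 `Cc1c(OCCCCOc2ccc(C(=O)O)c(Cl)c2)ccc(C(=O)CC(C)C)c1O` differs from compound 3 by isopropyl in place of cyclopentyl on a saturated chain carbon bound to a carbonyl carbon; cut one bond further out, the change reads cyclopentylmethyl to isobutyl, or (cyclopentylmethyl)carbonyl to isobutylcarbonyl. Among the measured compounds shown here, no measured step follows this change, so the step of a 2.0-fold lower number from compound 1 to compound 2 (0.30 log units; within the scatter) does not bear on it directly. What the data show is that both compounds carrying the isobutylcarbonyl of compound 4 sit below compound 3: compound 1 at 192 nM and compound 2 at 96 nM. On that basis a lower number is expected for compound 4, with the step of a 3.2-fold lower number from compound 3 to compound 4 (0.50 log units; beyond the scatter) estimated as moderate and of uncertain size. Compound 4 is therefore estimated at 160 nM in this assay, in the range 60 nM to 450 nM.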

Compound 4, half-maximal effective concentration: 151 nM
Beside the measured number, compound 4's estimate is 1.1-fold (0.03 log units) above it; measured number inside the range.
By their numbers in this assay, from the lowest: compounds 2, 4 and 1 (each within the scatter of the next); then compound 3.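

In this assay the ketone side chain gets its first matched comparison, and it shows that this position moves the number: with isopropyl in place of cyclopentyl on a saturated chain carbon bound to a carbonyl carbon, the change is (a 3.4-fold lower number from compound 3 to compound 4 (0.53 log units; beyond the scatter)). With the isobutylcarbonyl held fixed, the aromatic end does not separate the compounds, since both (a 1.6-fold higher number from compound 2 to compound 4 (0.20 log units; within the scatter)) and (a 1.3-fold lower number from compound 1 to compound 4 (0.10 log units; within the scatter)) stay within the scatter. No measurement shown accounts for the side chain step.

As far as these compounds go, whether the side chain step holds with 4-carboxy-2-chlorophenyl or 4-carboxy-2-methylphenyl in place of 4-carboxy-3-chlorophenyl remains open. The compounds shown also leave open how a cyclobutyl, a cyclohexyl or a tert-butyl group would read at this place.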